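The source may hold more compounds than are shown below. What is called first, only, known or untested is meant among the compounds shown, and "the series" means these compounds.

Working notes on the series, read in an ADME assay on the whole organism (plasma, strain 129/SvEvBrd x C57BL/6) for pharmacokinetics, with Mus musculus as the target, at a dose of 10 mg/kg by the oral route; a higher number here means more compound in the circulation at the dose given, a lower number less compound in the circulation. Compound 1 `CC(F)(F)c1nc([C@@H](O)[C@H](O)[C@H](O)CO)c[nH]1` gives 1190 ng.h/mL, compound 2 `Cc1nc(-c2nc([C@@H](O)[C@H](O)[C@H](O)CO)c[nH]2)cs1` gives 1970 ng.h/mL, and compound 3 `OC[C@@H](O)[C@@H](O)[C@H](O)c1c[nH]c(-c2cscn2)n1` gives 1570 ng.h/mL. Compound 3 therefore stands within the scatter of both other compounds, and the three numbers do not separate.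

The next step leads to compound 4 `OC[C@@H](O)[C@@H](O)[C@H](O)c1c[nH]c(-c2ncc[nH]2)n1`, not yet measured: 1H-imidazol-2-yl in place of 1,3-thiazol-4-yl on an aromatic carbon. The change is 1H-imidazol-2-yl in place of 1,3-thiazol-4-yl, on an aromatic carbon of a five-membered aromatic ring with 2 nitrogen, between two ring nitrogen atoms.

Two measured steps change the group at this same place: a 1.3-fold higher number from compound 1 to compound 3 (0.12 log units; within the scatter) and a 1.7-fold higher number from compound 1 to compound 2 (0.22 log units; within the scatter). A third, a 1.3-fold lower number from compound 2 to compound 3 (0.10 log units; within the scatter), changes only a methyl on the thiazole. All three stay within the scatter, so the series has so far shown little response in this read-out. Within the data shown here, no measured compound carries 1H-imidazol-2-yl, which leaves the direction open and the range wide.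

The estimated step is a 1.2-fold lower number from compound 3 to compound 4 (0.08 log units; within the scatter), and no change beyond the scatter is expected. For compound 4 the expected value is 1300 ng.h/mL, with an estimated range from 500 ng.h/mL to 3400 ng.h/mL.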

Compound 4, area under the concentration-time curve: 1500 ng.h/mL
The estimate for compound 4 lay 1.2-fold (0.06 log units) below the measured number; the measured number falls inside the stated range.
By their numbers in this assay, from the lowest: compounds 1, 4, 3 and 2 (each within the scatter of the next).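

In this assay, 1H-imidazol-2-yl in place of 1,3-thiazol-4-yl gives a 1.0-fold lower number from compound 3 to compound 4 (0.02 log units; within the scatter), and the two other steps that end at this group, a 1.3-fold lower number from compound 2 to compound 4 (0.12 log units; within the scatter) and a 1.3-fold higher number from compound 1 to compound 4 (0.10 log units; within the scatter), also stay within the scatter. Among these compounds, this is the first group at this position, on an aromatic carbon between two ring nitrogen atoms, to bring a hydrogen-bond donor, and across these four compounds the swap from a ring without a donor to a ring with one does not separate the numbers. Nothing measured here offers an explanation for how closely the numbers stay together.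

All the groups shown at this position are small, so it remains open whether a primary amine, a carboxylic acid, a phenyl ring or a longer alkyl chain there would move the number beyond the scatter. Every compound also keeps the shared core unchanged, which leaves open whether removing a hydroxyl group from its chain would have a larger effect than any change at this position.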